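The source may report more compounds than this note shows. Statements on the series, on what has been measured and on what is new or still open speak of the compounds shown alone.

Measured compounds:
- Compound 1 `CCOC(=O)c1c(-c2cccc(OC)c2)[nH]c2cc(OC)c(F)cc2c1=O`: in an ADME assay on HEK293 cells (Homo sapiens) for cytotoxicity, read by luminescence, with a stated time of 72 h (on this read-out higher numbers stand for an effect only at larger amounts of compound and lower numbers for an effect already at smaller amounts), compound 1 gives > 22000 nM, which is a limit of the assay and not a number.
- Compound 2 `CCOC(=O)c1c(-c2cccc(OC(F)(F)F)c2)[nH]c2cc(OC)c(F)cc2c1=O`: in this assay compound 2 gives > 22000 nM, again a limit rather than a number.

Within the data shown here, both values sit at the limit of > 22000 nM in this assay, at which 2 of the 2 values shown sit, so the only measured step, a step that the two limits leave unreadable from compound 1 to compound 2, cannot be read in size or direction; all that the two values show is that neither compound reached a measurable effect within the tested range. Compound 2 therefore stands at the limit of this assay, with no number of its own.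

The next compound, compound 3 `CCOC(=O)c1c(-c2cccc(Br)c2)[nH]c2cc(OC)c(F)cc2c1=O`, differs from compound 2 by bromo in place of trifluoromethoxy on an aromatic carbon. Among the measured compounds shown here, the one measured step changes the same position of the ring, but since it is unreadable, it gives no size to expect; there is no evidence of a step beyond the scatter in either direction, and no reason to expect compound 3 to leave the limit.

Compound 3 is thus expected to give about 30000 nM, in a range from 10000 nM to 100000 nM. The expected step, a step that the limit leaves unreadable from compound 2 to compound 3, is estimated to stay within the usual scatter.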

Compound 3, half-maximal effective concentration: > 22000 nM
Compound 3 was reported as a limit (the forecaster's own chance of this, stated with the estimate: 75%); the middle value does not contradict the limit.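

Compound 3 also gives only a limit of the assay, as do compound 1 and compound 2, so the steps from compound 1 and from compound 2 to compound 3 cannot be read in size or direction: the limit of > 22000 nM in this assay, at which 3 of the 3 values shown sit.

These three compounds leave open whether any group at this place on the ring gives a measurable effect in this assay.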